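Swapping a benzofuran for an ethynyl group on a nucleoside

A few compounds are considered here, and "the series" means these few. Any claim that something is new, unique, unknown or untested is made for them only; others in the source may bear on it.

Among the measured compounds shown here, compound 3, with structure `C[C@]1(CO)O[C@@H](n2cc(-c3cc4ccccc4o3)c3c(N)ncnc32)[C@H](O)[C@@H]1O`, is the only member of this small set to give an actual number in an ADME assay on Huh-7 cells (Homo sapiens) for cytotoxicity; a lower number here means that less compound is tolerated, a higher number that more compound is tolerated. For compound 3 the result is 31100 nM. Compound 1, with structure `C[C@]1(CO)O[C@@H](n2cc(-c3ccco3)c3c(N)ncnc32)[C@H](O)[C@@H]1O`, is reported only as a limit of the assay, > 44000 nM. Compound 2, with structure `C[C@]1(CO)O[C@@H](n2cc(-c3cccs3)c3c(N)ncnc32)[C@H](O)[C@@H]1O`, likewise sits at a limit, > 44000 nM. Because (the limit of > 44000 nM in this assay, at which 2 of the 3 values shown sit), the step that the two limits leave unreadable from compound 1 to compound 2 cannot be sized. The steps of an at least 1.4-fold lower number from compound 1 to compound 3 (0.15 log units; that floor lies within the scatter) and an at least 1.4-fold lower number from compound 2 to compound 3 (0.15 log units; that floor lies within the scatter) both run toward the larger benzofuran group. Compound 4, with structure `C#Cc1cn([C@@H]2O[C@](C)(CO)[C@@H](O)[C@H]2O)c2ncnc(N)c12`, carries the change (ethynyl in place of 1-benzofuran-2-yl on an aromatic carbon). For the measured compounds named here, no measured step replaces a large group with one so small, but both measured steps toward the larger group went downward, so the move toward a smaller group is expected to run the other way, back toward the limit. For compound 4 the expected step is a 1.4-fold higher number from compound 3 to compound 4 (0.15 log units; within the scatter). Compound 4 is therefore expected to give about 44000 nM in this assay, with a plausible range from 25000 nM to 90000 nM.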

Compound 4, half-maximal cytotoxic concentration: 32300 nM
Estimate against measurement, compound 4: 1.4-fold (0.13 log units) above, within the range that was stated.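

Exchanging 1-benzofuran-2-yl for the far smaller ethynyl gives a 1.0-fold higher number from compound 3 to compound 4 (0.02 log units; within the scatter), so among these compounds group size alone does not set the number in this assay at this aromatic carbon, and compound 4 goes against the idea that a smaller group here stays at the limit. The other two new steps, an at least 1.3-fold lower number from compound 2 to compound 4 (0.13 log units; that floor lies within the scatter) and an at least 1.3-fold lower number from compound 1 to compound 4 (0.13 log units; that floor lies within the scatter), have the same direction as the steps to compound 3, though neither floor clears the scatter. Their full size cannot be read because compound 1 and compound 2 are reported as a limit rather than a number: the limit of > 44000 nM in this assay, at which 2 of the 4 values shown sit.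

Still open, going by these compounds, is how an amine or a carboxylic acid on this aromatic carbon would read in this assay. So is whether a longer chain carrying the triple bond would read like compound 4.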